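This account rests on a few compounds, and the source may have more. Where it says the series, first, only, none or still open, it means among the compounds named here.

Values in a physicochemical assay for solubility, in phosphate buffer, measured as kinetic solubility, with a stated time of 1 h, at pH 7.4; on this read-out higher numbers stand for higher solubility and lower numbers for lower solubility:
- compound 1 `CC(C)(c1cc([C@@]23CCOC[C@@H]2C3)nc(-c2cccc(O)c2)n1)S(C)(=O)=O`: 148 ug/mL
- compound 2 `Oc1cccc(-c2nccc([C@@]34CCOC[C@@H]3C4)n2)c1`: 123 ug/mL

Compound 2 and compound 1 lie within the scatter of each other, so neither can be ranked. Compound 3 `CS(=O)(=O)Cc1cc([C@@]23CCOC[C@@H]2C3)nc(-c2cccc(O)c2)n1` carries (methylsulfonyl)methyl in place of hydrogen on an aromatic carbon. For the measured compounds named here, the one measured step that bears on this is a 1.2-fold lower number from compound 1 to compound 2 (0.08 log units; within the scatter), hydrogen in place of 1-methyl-1-(methylsulfonyl)ethyl on an aromatic carbon, and it stays within the scatter. On that single step, no change beyond the scatter is expected in this assay. The expected step is a 1.1-fold higher number from compound 2 to compound 3 (0.02 log units; within the scatter). For compound 3 the estimated value is 130 ug/mL, with an expected range of 65 ug/mL to 260 ug/mL.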

Compound 3, solubility: 145 ug/mL
Estimate against measurement, compound 3: 1.1-fold (0.05 log units) below; low and high end bracket the measured number.
By their numbers in this assay, from the lowest: compounds 2, 3 and 1 (each within the scatter of the next).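

In this assay the step for (methylsulfonyl)methyl on this aromatic carbon is a 1.2-fold higher number from compound 2 to compound 3 (0.07 log units; within the scatter) and stays within the scatter. Exchanging 1-methyl-1-(methylsulfonyl)ethyl for (methylsulfonyl)methyl at the same place gives a 1.0-fold lower number from compound 1 to compound 3 (0.01 log units; within the scatter) and also stays within the scatter, so neither the presence of either chain nor the difference between them separates these compounds on this read-out. No measurement available here offers a cause for these steps.

Going by these compounds, whether an amine or a carboxylic acid on this aromatic carbon would give a step beyond the scatter remains open. The same holds for a longer chain carrying the methylsulfonyl group.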